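A few compounds are considered here, and "the series" means these few. Any claim that something is new, unique, unknown or untested is made for them only; others in the source may bear on it.

Measured so far:
compound 1, `O=C(Nc1cc(-c2ccccc2)nn1-c1ccccc1)c1ccccc1Cl`, 2500 nM
compound 2, `O=C(Nc1cc(-c2ccccc2)nn1-c1ccccc1)c1ccsc1`, 1800 nM
compound 3, `Cc1cccc(C(=O)Nc2cc(-c3ccccc3)nn2-c2ccccc2)c1`, 90 nM

All three share the same core and differ only in the group on the carbonyl carbon. In an assay on CHO cells with metabotropic glutamate receptor 5 (Homo sapiens) as the target (on this read-out lower numbers stand for an effect already at smaller amounts and higher numbers for an effect only at larger amounts of compound), compound 1 gives the highest of the three numbers. The move to compound 2 changes little: a 1.4-fold lower number from compound 1 to compound 2 (0.14 log units; within the scatter). The move to compound 3 is a different matter: a 28-fold lower number from compound 1 to compound 3 (1.44 log units; beyond the scatter), and the same holds from compound 2, a 20-fold lower number from compound 2 to compound 3 (1.30 log units; beyond the scatter).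

Compound 4, `O=C(Nc1cc(-c2ccccc2)nn1-c1ccccc1)c1ccc(F)c(F)c1`, has not yet been measured. It differs from compound 1 at the same place as the others: 3,4-difluorophenyl in place of 2-chlorophenyl on a carbonyl carbon. Two of the measured steps bear on this change. The exchange of 2-chlorophenyl for another aromatic ring was once nearly neutral and once large, so a six-membered carbon ring carrying small substituents appears able to give a markedly lower number, as compound 3 shows, though a single case is thin ground. The number for compound 4 is therefore expected to fall below that of compound 1, by about a 5.6-fold lower number from compound 1 to compound 4 (0.74 log units; beyond the scatter), while a result close to compound 1 cannot be ruled out. For compound 4 the estimate in this assay is 450 nM, with a range from 100 nM to 2000 nM.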

Compound 4, half-maximal effective concentration: 10 nM
Beside the measured number, compound 4's estimate is 45-fold (1.65 log units) above it, outside the stated range (below it).
By their numbers in this assay, from the lowest: compound 4; then compound 3; then compounds 2 and 1 (each within the scatter of the next).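

In this assay, among these compounds, the group on the carbonyl carbon turns out to move the number much further than the earlier compounds showed: 3,4-difluorophenyl gives the steps (a 250-fold lower number from compound 1 to compound 4 (2.40 log units; beyond the scatter)) and (a 180-fold lower number from compound 2 to compound 4 (2.26 log units; beyond the scatter)), both larger than any step seen before. Compound 3 also no longer marks the low end of the series, since the exchange of its 3-methylphenyl for 3,4-difluorophenyl gives a further drop (a 9.0-fold lower number from compound 3 to compound 4 (0.95 log units; beyond the scatter)), so the low number of compound 3 was not the limit for a substituted six-membered ring at this place. Nothing at hand explains why these steps are so large.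

As far as these compounds go, what a single fluorine on this ring would give remains open. So does the effect of an amine, a carboxylic acid or a longer chain in place of the ring on the carbonyl carbon.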